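A few compounds are considered here, and "the series" means these few. Any claim that something is new, unique, unknown or untested is made for them only; others in the source may bear on it.

In a functional assay on U2OS cells for antagonist activity at C-X-C chemokine receptor type 3 (Homo sapiens), read by beta-arrestin recruitment (on this read-out higher numbers stand for weaker inhibition and lower numbers for stronger inhibition), compound 2 `CCOc1ncc(-c2nc(C(F)(F)F)sc2N2CCN(C(=O)Cn3nc(C)nc3C)[C@H](C)C2)cn1` gives 173 nM, while compound 1 `CCOc1ncc(-c2nc(C(F)(F)F)sc2N2CCN(C(=O)Cn3c(=O)oc4ccccc43)[C@H](C)C2)cn1` gives 99 nM; the two numbers lie within the scatter of each other, so neither compound can be set apart from the other. Compound 3 `Cc1nc(C)n(CC(=O)N2CCN(c3sc(C(F)(F)F)nc3-c3cnc(OC4CCC4)nc3)C[C@H]2C)n1` differs from compound 2 by cyclobutyl in place of ethyl on an oxygen on an aromatic ring. Going by the values given here, the one measured step, a 1.7-fold higher number from compound 1 to compound 2 (0.24 log units; within the scatter), concerns the group on the saturated chain carbon bound to the carbonyl carbon and does not bear on this change, so nothing beyond the scatter is expected in this assay. Compound 3 is therefore estimated at 170 nM, within 60 nM to 500 nM, meaning an expected 1.0-fold lower number from compound 2 to compound 3 (0.01 log units; within the scatter).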

Compound 3, half-maximal inhibitory concentration in the C-X-C chemokine receptor type 3 assay: 78 nM
For compound 3 the middle estimate is 2.2-fold (0.34 log units) above the measured one; low and high end bracket the measured number.
By their numbers in the C-X-C chemokine receptor type 3 assay, from the lowest: compounds 3, 1 and 2 (each within the scatter of the next, the first and the last beyond it).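

In the C-X-C chemokine receptor type 3 assay, cyclobutyl in place of ethyl on an oxygen on an aromatic ring gives a 2.2-fold lower number from compound 2 to compound 3 (0.35 log units; beyond the scatter), so this position, which the earlier pair left unchanged, responds to the group it carries. In a physicochemical assay for lipophilicity, at pH 7.4 (on this read-out higher numbers stand for higher lipophilicity and lower numbers for lower lipophilicity), the same change raises the number, with compound 2 at 2.8 and compound 3 at 3.6, so the stronger inhibition comes with higher lipophilicity: the measured distribution coefficient of compound 2, 2.8, and of compound 3, 3.6, a number 0.80 log units higher (beyond the scatter).

The compounds shown do not tell whether the ring itself or the added carbons account for the step. Nor do they show how an isopropyl group or an oxetane ring on that oxygen would read in either assay.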